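Fluoro substitution carried over between two related cores

A few compounds are considered here, and "the series" means these few. Any claim that something is new, unique, unknown or untested is made for them only; others in the source may bear on it.

Measured in a functional assay on G-361 cells (Homo sapiens) for inhibition, with a stated time of 72 h; a higher number here means a weaker inhibitor, a lower number a stronger inhibitor:
compound 1, `NC1CCC(Nc2nc(NCc3ccc(-c4ccccc4)cc3)c3ncn(C4CCCC4)c3n2)CC1`: 1020 nM
compound 2, `NC1CCC(Nc2nc(NCc3ccc(-c4cccc(F)c4)cc3)c3ncn(C4CCCC4)c3n2)CC1`: 815 nM
compound 3, `NC1CCC(Nc2nc(NCc3ccc(-c4ccccc4)nc3)c3ncn(C4CCCC4)c3n2)CC1`: 895 nM

Compound 1 and compound 2 differ by fluoro in place of hydrogen on an aromatic carbon; this change gave a 1.3-fold lower number from compound 1 to compound 2 (0.10 log units; within the scatter). The two cores differ by 6-phenylpyridin-3-yl in place of 4-phenylphenyl on a saturated chain carbon bound to a nitrogen on an aromatic ring, and that change gave a 1.1-fold lower number from compound 1 to compound 3 (0.06 log units; within the scatter). All three measured values lie within the scatter of one another, so no order among them can be read from these numbers.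

Compound 4, `NC1CCC(Nc2nc(NCc3ccc(-c4cccc(F)c4)nc3)c3ncn(C4CCCC4)c3n2)CC1`, is not yet measured. It differs from compound 3 by fluoro in place of hydrogen on an aromatic carbon; the place given for this change is word for word the same as for the change from compound 1 to compound 2, so it is the same change, now made on the other core. The expected step for compound 4 is a 1.2-fold lower number from compound 3 to compound 4 (0.09 log units; within the scatter), a step of about the same size as a 1.3-fold lower number from compound 1 to compound 2 (0.10 log units; within the scatter). This expectation rests on the small size of the first fluoro step, which was only a 1.3-fold lower number from compound 1 to compound 2 (0.10 log units; within the scatter). It also rests on the small size of the core change, which was only a 1.1-fold lower number from compound 1 to compound 3 (0.06 log units; within the scatter). Compound 4 is therefore estimated at 720 nM, with a likely range from 400 nM to 1300 nM.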

Compound 4, half-maximal inhibitory concentration: 49 nM
Compound 4: the middle estimate sits 15-fold (1.17 log units) above what was measured, outside the stated range (below it).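

In this assay, the fluoro change made on the 6-phenylpyridin-3-yl core gave an 18-fold lower number from compound 3 to compound 4 (1.26 log units; beyond the scatter). The same change on the 4-phenylphenyl core gave a step within the scatter, so the size of the step did not carry over from one core to the other: the same change on two cores in this assay, a 1.3-fold lower number (0.10 log units; within the scatter) from compound 1 to compound 2 and an 18-fold lower number (1.26 log units; beyond the scatter) from compound 3 to compound 4, 15-fold (1.16 log units) apart, beyond the scatter of two such steps

This comparison rests on a single pair of compounds per core in a single cell assay, so it shows that the effect of phenyl to 3-fluorophenyl depends on the core in this one case, but it does not show why, nor whether the same holds for any other core.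

The compounds shown leave open whether the large step is specific to fluoro or would also appear with chloro, methoxy or a nitrile in its place on the 6-phenylpyridin-3-yl core. Also open, going by these compounds, is whether the step would be seen in any read-out other than this cell assay.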